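The source may report more compounds than this note shows. Statements on the series, on what has been measured and on what is new or still open speak of the compounds shown alone.

Three compounds share one core, a ring system that carries an acetic acid group, and they differ only in the group joined to that core through an ether oxygen. Compound 1 `Cc1cc(COc2ccc3c(c2)OCC3CC(=O)O)nn1-c1ccccc1` and compound 2 `O=C(O)CC1COc2cc(OCc3cc(-c4ccccc4)on3)ccc21` each carry such a group, and so does compound 3 `Cc1nc(-c2cccs2)sc1COc1ccc2c(c1)OCC2CC(=O)O`, whose group ends in a thiophen-2-yl ring. In a functional assay on CHO cells for agonist activity at Free fatty acid receptor 1 (Homo sapiens), read by FLIPR and calcium flux, tested at 100 nM (a higher number here means a stronger effect of the compound at the concentration tested, a lower number a weaker effect), compound 1 gives 0.98%, and compound 2 gives 0.84%; these two numbers lie within the usual scatter of each other. Compound 3 gives 35.2%, the highest of the three numbers and beyond the scatter above both of the others.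

Compound 4 `Cc1nc(-c2ccc(Cl)s2)sc1COc1ccc2c(c1)OCC2CC(=O)O` has not yet been measured. It differs from compound 3 by chloro in place of hydrogen on an aromatic carbon, so that thiophen-2-yl becomes 5-chlorothiophen-2-yl. Among the compounds with values here, no pair of measured compounds shows this change, so its effect is unknown. Given that compound 3 already gives 35.2%, the step of a number 4.8 percentage points higher from compound 3 to compound 4 (within the scatter) is expected to be small and within the scatter. Compound 4 is therefore estimated at 40%, within a range from 15% to 65%.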

Compound 4, a percentage reported as activity, at one concentration (the size of the read-out at that concentration, not a potency): 8.34%
Compound 4: middle estimate off by 31.7 percentage points, on the high side; measured number below the stated range.
By their numbers in this assay, from the lowest: compounds 2, 1 and 4 (each within the scatter of the next); then compound 3.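

In this assay, chloro in place of hydrogen on the thiophen-2-yl ring of compound 3 gives a number 26.9 percentage points lower from compound 3 to compound 4 (beyond the scatter). This shows that the aromatic carbon next to the ring sulfur is not a place where a change passes unnoticed: a single added chlorine atom alters the read-out at the tested concentration. Nothing available here bears on why the number falls.

The compounds shown leave open whether this fall belongs to chloro alone or would follow any group on this carbon, as a fluoro or a methyl group there could show. This single pair also leaves open whether chloro would act in the same way on other groups joined to the shared core.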